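The source may hold more compounds than are shown below. What is called first, only, known or untested is meant among the compounds shown, and "the series" means these compounds.

In an ADME assay on MT4 cells (Homo sapiens) for cytotoxicity (on this read-out higher numbers stand for lower toxicity in this test and lower numbers for higher toxicity in this test), compound 1 `Cc1ccc(/C=N/N(C(=O)c2ccccc2)C(=O)c2ccncc2)cc1` gives 42 ug/mL, the highest of the three numbers available. Compound 3 `COc1cccc(OC)c1/C=N/N(C(=O)c1ccccc1)C(=O)c1ccncc1` gives 12 ug/mL and compound 2 `COc1cccc(OC)c1/C=N/NC(=O)c1ccncc1` gives 9 ug/mL, both of them beyond the scatter below compound 1. Within the data shown here, the only measured step between neighbours, a 1.3-fold higher number from compound 2 to compound 3 (0.12 log units; within the scatter), changes a different place and stays within the scatter, so it says little about the ring substituent. Compound 4 `CSc1ccc(/C=N/N(C(=O)c2ccccc2)C(=O)c2ccncc2)cc1` differs from compound 1 by methylsulfanyl in place of methyl on an aromatic carbon. Among the measured compounds shown here, no measured pair shows this exchange, so nothing argues for a shift beyond the scatter, and the expected step is small, a 1.1-fold lower number from compound 1 to compound 4 (0.02 log units; within the scatter). Compound 4 is therefore estimated at 40 ug/mL, with a range from 20 ug/mL to 80 ug/mL.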

Compound 4, half-maximal cytotoxic concentration: 69 ug/mL
Beside the measured number, compound 4's estimate is 1.7-fold (0.24 log units) below it; the range from low to high includes it.
By their numbers in this assay, from the lowest: compounds 2 and 3 (each within the scatter of the next); then compounds 1 and 4 (each within the scatter of the next).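

Placing methylsulfanyl where methyl stood, on an aromatic carbon para to a large group, gives a 1.6-fold higher number from compound 1 to compound 4 (0.22 log units; within the scatter) in this assay. This position therefore accepts the exchange with no step beyond the scatter, which the earlier step, made on an amide-type nitrogen, could not show. Nothing measured here offers an explanation for this result. On these data alone, whether an amine, a carboxylic acid or a longer chain at this position would also stay within the scatter remains open. So does whether the same exchange would give a similar step on the core of compound 2.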